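A few compounds are considered here, and "the series" means these few. Any claim that something is new, unique, unknown or untested is made for them only; others in the source may bear on it.

- Compound 1 `Cc1cc(C)cc(NS(=O)(=O)c2ccc(N3CCNC3=O)cc2)c1`: 110 nM
- Compound 2 `COc1cc(NS(=O)(=O)c2ccc(N3CCNC3=O)cc2)cc(OC)c1`: 110 nM

In a functional assay on K562 cells (Homo sapiens) for antiproliferative activity, read by sulforhodamine B assay, with a stated time of 48 h (on this read-out lower numbers stand for stronger inhibition and higher numbers for weaker inhibition), compound 2 gives 110 nM, the same reading at the digits shown as compound 1 at 110 nM. Compound 3 `COc1cccc(NS(=O)(=O)c2ccc(N3CCNC3=O)cc2)c1` differs from compound 2 by having hydrogen in place of methoxy on an aromatic carbon. For the measured compounds named here, no measured compound shows this change directly, so the data offer no step to follow. A moderate move toward higher numbers in this assay, meaning somewhat weaker inhibition, is nevertheless expected, though it may not clear the usual scatter. The expected size is a 2.0-fold higher number from compound 2 to compound 3 (0.30 log units; within the scatter), and this remains an estimate. The estimated value for compound 3 is 220 nM, with an expected range from 80 nM to 700 nM.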

Compound 3, half-maximal inhibitory concentration: 230 nM
Compound 3: the middle estimate sits 1.0-fold (0.02 log units) below what was measured; measured number inside the range.
By their numbers in this assay, from the lowest: compounds 1 and 2 (each within the scatter of the next); then compound 3.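

In this assay, for the compounds shown here, the change of hydrogen in place of methoxy on an aromatic carbon gives a 2.1-fold higher number from compound 2 to compound 3 (0.32 log units; beyond the scatter) and so provides the first step at this position that lies beyond the scatter, though only modestly. The change to 3-methoxyphenyl in place of 3,5-dimethylphenyl on the sulfonamide nitrogen gives a 2.1-fold higher number from compound 1 to compound 3 (0.32 log units; beyond the scatter) in the same assay, so the ring bearing a single methoxy group reads apart from both compounds that carry two groups, whereas compound 1 and compound 2 had shown no difference at the digits printed. No measurement at hand explains why this change weakens inhibition. Going by these compounds, it remains open whether a single chlorine, fluorine or amine at this place would give a reading closer to that of compound 2. On these data alone, the reading of a plain phenyl ring on the sulfonamide nitrogen also remains open.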